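Urea terminus variation from compound 2 to compound 3

The source may report more compounds than this note shows. Statements on the series, on what has been measured and on what is new or still open speak of the compounds shown alone.

compound 1 `Cc1cc(C(=O)N2CCCCc3ccccc32)ccc1CNC(=O)Nc1ccccc1`: 130 nM
compound 2 `COC(=O)CNC(=O)NCc1ccc(C(=O)N2CCCCc3ccccc32)cc1C`: 37 nM

In a functional assay on HEK293 cells for agonist activity at Vasopressin V2 receptor (Homo sapiens), read by a luciferase reporter and cAMP accumulation (on this read-out lower numbers stand for an effect already at smaller amounts and higher numbers for an effect only at larger amounts of compound), compound 1 gives 130 nM and compound 2 gives 37 nM. Among the measured compounds shown here, compound 2 thus holds the lowest of the two numbers, with compound 1 as its only neighbour. Compound 3 `CCN(CC)C(=O)[C@@H]1CCCN1C(=O)NCc1ccc(C(=O)N2CCCCc3ccccc32)cc1C` differs from compound 2 by 2-(diethylcarbamoyl)pyrrolidin-1-yl in place of ((methoxycarbonyl)methyl)amino on a carbonyl carbon. For the measured compounds named here, the single measured step, a 3.5-fold lower number from compound 1 to compound 2 (0.55 log units; beyond the scatter), touches the same urea position but exchanges a different group, so it bears only loosely on this change; the loss of the donor is untested. Compound 3 is therefore expected near 50 nM, within 12 nM to 200 nM. This estimate for compound 3 means a 1.4-fold higher number from compound 2 to compound 3 (0.13 log units; within the scatter).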

Compound 3, half-maximal effective concentration: 350 nM
Estimate against measurement, compound 3: 7.0-fold (0.85 log units) below; measured number above the stated range.
By their numbers in this assay, from the lowest: compound 2; then compound 1; then compound 3.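

At this carbonyl carbon, the gain seen with ((methoxycarbonyl)methyl)amino does not extend to 2-(diethylcarbamoyl)pyrrolidin-1-yl: a 9.5-fold higher number from compound 2 to compound 3 (0.98 log units; beyond the scatter) is beyond the scatter. The same group also falls behind the anilino terminus, with a 2.7-fold higher number from compound 1 to compound 3 (0.43 log units; beyond the scatter), leaving compound 3 with the highest number of the three. The change removes the urea hydrogen and adds a ring and a diethylamide at once, and nothing available accounts for the shift.

Which of these parts carries the rise remains open. A plain pyrrolidin-1-yl, or a carboxylic acid in place of the methyl ester of compound 2, would help separate them.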